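Fluoro in Place of Trifluoromethyl on Compound 2

The source may hold more compounds than are shown below. What is called first, only, known or untested is meant among the compounds shown, and "the series" means these compounds.

Measured so far:
Compound 1 `O=C1COc2ccc(-c3[nH]c(-c4c[nH]c5ncccc45)nc3-c3ccccc3)cc2N1` gives 53.5% in a functional assay on DLD-1 cells (Homo sapiens) for cytotoxicity, read by colorimetric assay and MTT assay, with a stated time of 3 days, tested at 20 uM; on this read-out lower numbers stand for a stronger effect and higher numbers for a weaker effect at the one concentration tested.
Compound 2 `O=C1COc2ccc(-c3[nH]c(-c4ccc(C(F)(F)F)cc4)nc3-c3ccccc3)cc2N1` gives 12.1% in this assay.

Compound 2 stands lowest of the two numbers, the stronger effect, separated from compound 1 by a number 41.4 percentage points lower from compound 1 to compound 2 (beyond the scatter). Compound 3 `O=C1COc2ccc(-c3[nH]c(-c4ccc(F)cc4)nc3-c3ccccc3)cc2N1` differs from compound 2 by fluoro in place of trifluoromethyl on an aromatic carbon. Going by the values given here, the one measured step exchanges a whole aryl group rather than a single substituent on it, so it offers no direct guidance for this change. Compound 3 is therefore expected to stay broadly near compound 2, with a modest weakening as the likelier direction, a step of a number 15.9 percentage points higher from compound 2 to compound 3 (beyond the scatter). The estimate for compound 3 is 28%, ranging from 8% to 55%.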

Compound 3, a percentage reported as activity, at one concentration (the size of the read-out at that concentration, not a potency): 29.5%
Compound 3: middle estimate off by 1.5 percentage points, on the low side; low and high end bracket the measured number.
By their numbers in this assay, from the lowest: compound 2; then compound 3; then compound 1.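

In this assay, changing only the substituent on this aryl ring, from trifluoromethyl to fluoro, gives a number 17.4 percentage points higher from compound 2 to compound 3 (beyond the scatter) and so shows that this position responds to a single group, not only to an exchange of the whole aryl group. The 4-fluorophenyl group also keeps the lower reading relative to the aryl group of compound 1, with a number 24 percentage points lower from compound 1 to compound 3 (beyond the scatter) in this comparison. No supporting evidence accounts for either step.

Two substituents at this place define no trend. The compounds shown leave open how a chloro, a methoxy, an amine or a carboxylic acid there would read.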